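The source may hold more compounds than are shown below. What is called first, only, known or untested is meant among the compounds shown, and "the series" means these compounds.

Working notes on the series. In a functional assay on HepG2 cells (Homo sapiens) for antiproliferative activity, read by MTT assay, with a stated time of 72 h (a higher number here means a weaker inhibitor, a lower number a stronger inhibitor), compound 1 (`O=C(N/N=C/c1ccccc1)Nc1ccc(Oc2ccnc3[nH]ccc23)c(F)c1`) gives 640 nM, and compound 2 (`O=C(N/N=C/c1cccc(Br)c1)Nc1ccc(Oc2ccnc3[nH]ccc23)c(F)c1`) gives 660 nM. Among the measured compounds shown here, these values lie within the scatter of each other, so compound 2 stands level with the only other measured compound. Next comes compound 3 (`O=C(N/N=C/c1ccc(Br)cc1)Nc1ccc(Oc2ccnc3[nH]ccc23)c(F)c1`), with the change 4-bromophenyl in place of 3-bromophenyl on a carbon with a double bond to nitrogen. For the measured compounds named here, only one measured step bears on this, bromo in place of hydrogen on an aromatic carbon, a 1.0-fold higher number from compound 1 to compound 2 (0.01 log units; within the scatter). That step stays within the scatter. Going by the values given here, no measured compound carries 4-bromophenyl, so the move itself remains untested. No change beyond the scatter is therefore expected in this assay. The expected step is a 1.1-fold lower number from compound 2 to compound 3 (0.03 log units; within the scatter). For compound 3 the estimated value is 620 nM, with an expected range of 260 nM to 1400 nM.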

Compound 3, half-maximal inhibitory concentration: 1000 nM
Estimate against measurement, compound 3: 1.6-fold (0.21 log units) below, and the stated range covers the measured number.
By their numbers in this assay, from the lowest: compounds 1, 2 and 3 (each within the scatter of the next).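

In this assay, 4-bromophenyl in place of 3-bromophenyl on the carbon with a double bond to nitrogen gives a 1.5-fold higher number from compound 2 to compound 3 (0.18 log units; within the scatter), so the move of the bromo group, untested until now, does not take the number outside the scatter. Bromo in place of hydrogen on an aromatic carbon, now read at the second ring location, gives a 1.6-fold higher number from compound 1 to compound 3 (0.19 log units; within the scatter), so neither bromophenyl group separates from the plain phenyl group in this assay. Nothing at hand gives a measured reason for these small differences.

As far as these compounds go, the three compounds span only phenyl and bromophenyl at this position, so how far the number depends on the group there remains open. A methoxy group, an amine or a carboxylic acid on this ring could show whether any replacement moves the number beyond the scatter.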